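The compounds below may be only part of what the source reports. "The series", "measured", "known", "first", "only" and "open" are said of these compounds alone.

Among the compounds with values here, in a functional assay on MCF7 cells (Homo sapiens) for antiproliferative activity, read by MTT assay, with a stated time of 48 h (a lower number here means a stronger inhibitor, a higher number a weaker inhibitor), compound 1 `CCn1c(C(=O)NCCN)ccc1C(CC)(CC)c1ccc(OCCC(O)(CC)CC)c(C)c1` gives 670 nM, while compound 2 `CCOC(=O)CN(C)C(=O)c1ccc(C(CC)(CC)c2ccc(OCCC(O)(CC)CC)c(C)c2)n1CC` gives 3210 nM, the higher, and so weaker, of the two numbers measured so far. Compound 3 `CCn1c(C(=O)NC(CC(=O)O)C(=O)OC)ccc1C(CC)(CC)c1ccc(OCCC(O)(CC)CC)c(C)c1` keeps the shared core and changes the group on the same carbonyl carbon: a group of 10 heavy atoms (5 carbon, 1 nitrogen, 4 oxygen; no ring) in place of a group of 8 heavy atoms (5 carbon, 1 nitrogen, 2 oxygen; no ring), on a carbonyl carbon. Within the data shown here, only one measured step bears on this place, a 4.8-fold higher number from compound 1 to compound 2 (0.68 log units; beyond the scatter). It is modest but lies beyond the scatter. A single step offers a rough size for changes at this carbonyl carbon, but it gives no firm direction for a group not yet tested. A step no larger than that one is therefore expected in this assay, leaning slightly towards a lower number and possibly staying within the scatter. The estimated step is a 1.5-fold lower number from compound 2 to compound 3 (0.16 log units; within the scatter). For compound 3, the expected value is 2200 nM, within an estimated range of 700 nM to 7000 nM.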

Compound 3, half-maximal inhibitory concentration: 10200 nM
Compound 3: the middle estimate sits 4.6-fold (0.67 log units) below what was measured; the measured number lies above the stated range.
By their numbers in this assay, from the lowest: compound 1; then compound 2; then compound 3.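

In this assay, the carbonyl carbon now gives a second change beyond the scatter, a 3.2-fold higher number from compound 2 to compound 3 (0.50 log units; beyond the scatter), so the number at this place has risen with each swap away from the (2-aminoethyl)amino group. Measured against the starting compound, the rise is larger, a 15-fold higher number from compound 1 to compound 3 (1.18 log units; beyond the scatter), and hydrogen-bond donors in the entering group, absent from the ((ethoxycarbonyl)methyl)(methyl)amino group it replaces, do not restore the lower number. No measurement available here explains these rises.

Within the data shown here, with only three compounds, it remains open whether the primary amine at the end of the (2-aminoethyl)amino group matters, or whether the shorter group on the amide-type nitrogen is what counts. A (3-aminopropyl)amino group or a piperazine on this carbonyl carbon would help separate those two readings.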